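A few compounds are considered here, and "the series" means these few. Any claim that something is new, unique, unknown or untested is made for them only; others in the source may bear on it.

Measured so far in a functional assay on ECa-109 cells for inhibition, with ECa-109 cell line (Homo sapiens) as the target, read by sulforhodamine B assay; on this read-out lower numbers stand for stronger inhibition and higher numbers for weaker inhibition:
compound 1 `O=C1C(Nc2ccc(I)cc2)=CC(=O)c2c1nc1n2[C@H]2OC[C@@H](O)[C@H]2OC1` gives 2530 nM.
compound 2 `O=C1C(NC2CCCC2)=CC(=O)c2c1nc1n2[C@H]2OC[C@@H](O)[C@H]2OC1` gives only a limit, > 16000 nM.
compound 3 `COc1ccccc1NC1=CC(=O)c2nc3n(c2C1=O)[C@H]1OC[C@@H](O)[C@H]1OC3` gives only a limit, > 4000 nM.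

Compound 3 thus stands at the limit of > 4000 nM in this assay, at which 1 of the 3 values shown sits, with no number of its own. One further value in this set is also a limit, (the limit of > 16000 nM in this assay, at which 1 of the 3 values shown sits). Compound 4 `O=C1C=C(Nc2ccccc2)C(=O)c2c1nc1n2[C@H]2OC[C@@H](O)[C@H]2OC1` differs from compound 3 by hydrogen in place of methoxy on an aromatic carbon. Within the data shown here, the only measured step, an at least 6.3-fold higher number from compound 1 to compound 2 (0.80 log units; beyond the scatter), swaps the whole aryl group for cyclopentyl and bears only loosely on removing a methoxy from the ring. Compound 1, carrying 4-iodophenyl, gives a number in this assay; compound 3, carrying 2-methoxyphenyl, does not. Compound 4 with plain phenyl is expected to land near the weaker of these, at 5000 nM (range 1500 nM to 20000 nM), and may again return only a limit. The expected step is a step that the limit leaves unreadable from compound 3 to compound 4.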

Compound 4, half-maximal inhibitory concentration: 4970 nM
Compound 4: the middle estimate sits 1.0-fold (0.00 log units) above what was measured; the measured number falls inside the stated range.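

The step from compound 3 to compound 4 cannot be read, as compound 3 holds only a limit: the limit of > 4000 nM in this assay, at which 1 of the 4 values shown sits.

Whether hydrogen in place of methoxy changes inhibition in this assay, and in which direction, stays open with the compounds shown.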